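Swapping trifluoromethoxy for ethyl on the aryl ring

A few compounds are considered here, and "the series" means these few. Any claim that something is new, unique, unknown or untested is made for them only; others in the source may bear on it.

Measured compounds:
- Compound 1, `Cc1cccc(C)c1-c1cc2c(cn1)ncn2-c1ccc(OC(F)F)cc1`, gives 980 nM in a functional assay on HL-60 cells (Homo sapiens) for activation, read by flow cytometry, with a stated time of 4 days; a higher number here means that more compound is needed for the effect, a lower number that less compound is needed.
- Compound 2, `FC(F)Oc1ccc(-n2cnc3cnc(-c4ccccc4OC(F)(F)F)cc32)cc1`, gives 6900 nM in this assay.

Of the two numbers seen so far, compound 2 stands at the highest, so it needs the most compound to reach the half-maximal effect; its nearest neighbour is compound 1, whose number is lower by a margin that lies beyond the usual scatter of this assay. Compound 3, `CCc1ccccc1-c1cc2c(cn1)ncn2-c1ccc(OC(F)F)cc1`, has not been measured yet. Relative to compound 2 its structure changes in one place: ethyl in place of trifluoromethoxy on an aromatic carbon, on an aromatic carbon of a six-membered aromatic ring of carbon only, ortho to a large group.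

Going by the values given here, no measured pair shows this particular exchange, so the size of the step cannot be read from the data. Among the compounds with values here, the only guide is that compound 1, which carries small alkyl groups on the same ring rather than trifluoromethoxy, gives 980 nM. On that basis compound 3 is expected to move toward a lower number, by a step of a 3.8-fold lower number from compound 2 to compound 3 (0.58 log units; beyond the scatter), landing at an estimated 1800 nM with a range from 600 nM to 5500 nM.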

Compound 3, half-maximal effective concentration: 2900 nM
For compound 3 the middle estimate is 1.6-fold (0.21 log units) below the measured one; low and high end bracket the measured number.
By their numbers in this assay, from the lowest: compound 1; then compound 3; then compound 2.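

Ethyl in place of trifluoromethoxy on this aromatic carbon gives, in this assay, a 2.4-fold lower number from compound 2 to compound 3 (0.38 log units; beyond the scatter) as a direct exchange with the rest of the structure unchanged, so the group at this place does affect the amount of compound needed, though the step is modest. With 2-ethylphenyl in place of 2,6-dimethylphenyl there is a 3.0-fold higher number from compound 1 to compound 3 (0.47 log units; beyond the scatter) and this modest step is also beyond the usual scatter, so the ethyl compound does not match the compound carrying two methyl groups on this ring. The three aryl groups can now be placed in order by direct steps, with 2,6-dimethylphenyl needing the least compound and the trifluoromethoxy-bearing ring the most, but no supporting measurement explains the size of either step.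

The compounds shown leave open what a propyl chain, a methoxy group or an amine would do at this same aromatic carbon. They also leave open whether this order of the three aryl groups would hold with a group other than difluoromethoxy on the other aromatic ring.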